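Swapping the aryl group on a nitrogen-rich ring: cytotoxicity outlook

The source may hold more compounds than are shown below. What is called first, only, known or untested is meant among the compounds shown, and "the series" means these compounds.

Measured compounds:
- compound 1, `CC(=O)OC[C@H]1O[C@H](OC[C@@H](Cn2cc(CN(c3nc(-c4cccc([N+](=O)[O-])c4)no3)C3CCCCC3)nn2)OC(C)=O)C=C[C@@H]1OC(C)=O`: 100 ug/mL
- compound 2, `C#CCOc1ccc(-c2noc(NC3CCCCC3)n2)cc1`: 38.3 ug/mL

In an ADME assay on RAW264.7 cells (Mus musculus) for cytotoxicity, read by MTT assay, with a stated time of 48 h (a higher number here means that more compound is tolerated, a lower number that less compound is tolerated), compound 1 gives 100 ug/mL, the highest of the two numbers. Compound 2, a much smaller molecule with the same five-membered ring, gives 38.3 ug/mL, a lower figure that lies beyond the usual scatter; the two structures differ in several places, so only the two values themselves can be compared.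

Compound 3, `COc1ccc(-c2noc(N(Cc3cn(C[C@H](CO[C@@H]4C=C[C@H](OC(C)=O)[C@@H](COC(C)=O)O4)OC(C)=O)nn3)C3CCCCC3)n2)cc1`, is not yet measured. It keeps the whole framework of compound 1 and changes one group: 4-methoxyphenyl in place of 3-nitrophenyl on an aromatic carbon. For the measured compounds named here, nothing among the measured pairs shows a change of this kind, so no step can be read off. Given that the rest of the molecule stays the same, compound 3 is expected to be tolerated at about the level of compound 1, with the step of no change at the digits printed from compound 1 to compound 3 (within the scatter) expected to stay within the scatter. The estimated value for compound 3 is 100 ug/mL, with a range from 50 ug/mL to 200 ug/mL.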

Compound 3, half-maximal cytotoxic concentration: 86.3 ug/mL
The estimate for compound 3 lay 1.2-fold (0.06 log units) above the measured number; measured number inside the range.
By their numbers in this assay, from the lowest: compound 2; then compounds 3 and 1 (each within the scatter of the next).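

With the rest of the molecule held fixed, putting 4-methoxyphenyl in place of 3-nitrophenyl gives, in this assay, a 1.2-fold lower number from compound 1 to compound 3 (0.06 log units; within the scatter). For the compounds shown here, this is the first direct reading at this position, on an aromatic carbon of the five-membered ring, and this read-out does not separate these two aryl groups even though their substituents differ. No measurement shown explains this result.

These two aryl groups leave open whether a phenyl ring carrying an amine or a carboxylic acid, or a longer alkyl chain at the same place, would give a number within the same scatter. Going by these compounds, it also remains open whether this same swap would read the same way on a framework other than that of compound 1.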